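Swapping the Ring Halogen for an Ester

The source may hold more compounds than are shown below. What is called first, only, known or untested is meant among the compounds shown, and "the series" means these compounds.

Going by the values given here, compound 2, with the structure `O=C(O)Cn1c(SCc2ccc(Cl)cc2)nc2ccccc21`, stands at the strong end of the three compounds measured so far: in an assay on HEK293 cells for displacement of a labelled ligand from prostaglandin D2 receptor 2 (Homo sapiens) (a higher number here means a weaker inhibitor, a lower number a stronger inhibitor), compound 2 gives 160 nM. Compound 3, `O=C(O)Cn1c(SCc2cccc(Br)c2)nc2ccccc21`, gives 370 nM, and compound 1, `CCOC(=O)CCCSc1nc2ccccc2n1CC(=O)O`, gives 4410 nM. The steps show how far apart they lie: a 28-fold lower number from compound 1 to compound 2 (1.44 log units; beyond the scatter), a 12-fold lower number from compound 1 to compound 3 (1.08 log units; beyond the scatter), and a 2.3-fold higher number from compound 2 to compound 3 (0.36 log units; beyond the scatter).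

Compound 4, `COC(=O)c1ccc(CSc2nc3ccccc3n2CC(=O)O)cc1`, is not yet measured. It differs from compound 2 in one place: methoxycarbonyl in place of chloro on an aromatic carbon. None of the three measured steps tests this particular exchange on the aromatic ring. The two large steps from compound 1 concern replacing a chain by a substituted phenyl ring, and the modest step from compound 2 to compound 3 compares two halogens at different places on that ring. The only ester seen so far sits on the chain of compound 1, which is a different position, so its weak number says little about compound 4.

Among the compounds with values here, with no direct precedent, a modest rise in number is the most cautious expectation, a 2.2-fold higher number from compound 2 to compound 4 (0.34 log units; beyond the scatter). Compound 4 is therefore estimated at 350 nM, within a range from 100 nM to 1200 nM.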

Compound 4, half-maximal inhibitory concentration: 10600 nM
Beside the measured number, compound 4's estimate is 30-fold (1.48 log units) below it; the measured number lies above the stated range.
By their numbers in this assay, from the lowest: compound 2; then compound 3; then compound 1; then compound 4.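

The aromatic carbon para to a large group turns out to be highly sensitive to what it carries: in this assay, methoxycarbonyl in place of chloro gives a 66-fold higher number from compound 2 to compound 4 (1.82 log units; beyond the scatter). Going by these compounds alone, until now, the only change on this ring was one halogen for another at a different place, and that step was far smaller, with a 2.3-fold higher number from compound 2 to compound 3 (0.36 log units; beyond the scatter), so the two halogen compounds gave no sign that a single exchange on the ring could cost this much. Keeping the substituted phenyl ring on the sulfur-bound carbon therefore does not by itself secure a low number, since compound 4 retains that ring and everything else in compound 2 apart from this one group, but no measurement here accounts for the size of the rise.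

From the compounds shown here alone, it remains open whether a methyl, a nitrile or an amide on the same aromatic carbon would stay close to compound 2 or rise as far as compound 4. Going by these compounds, it is also open how a plain ring carbon carrying only hydrogen would compare with chloro, and whether methoxycarbonyl would give the same result elsewhere on the ring.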